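The compounds below may be only part of what the source reports. "The series", "measured", "known", "first", "only" and "open" are said of these compounds alone.

The measured compounds, all sharing one core and differing only in the group on the sulfonyl sulfur:

Compound 1, `C=Cc1ccc(S(=O)(=O)Nc2ccc3oc(-c4ccccc4)nc3c2)cc1`, gives 53000 nM in an ADME assay on HEK293 cells (Homo sapiens) for cytotoxicity, read by resazurin assay, with a stated time of 48 h; on this read-out lower numbers stand for higher toxicity in this test and higher numbers for lower toxicity in this test.
Compound 2, `COc1cccc(S(=O)(=O)Nc2ccc3oc(-c4ccccc4)nc3c2)c1`, gives 63000 nM in this assay.
Compound 3, `O=S(=O)(Nc1ccc2oc(-c3ccccc3)nc2c1)c1cccc(O)c1`, gives in this assay only a limit, > 100000 nM.

Compound 3 therefore stands apart from the other two not by a number but by the fact that no number was reached: the limit of > 100000 nM in this assay, at which 1 of the 3 values shown sits. The three values lie close together, and none of the steps among them rises beyond the scatter: a 1.2-fold higher number from compound 1 to compound 2 (0.08 log units; within the scatter), an at least 1.8-fold higher number from compound 1 to compound 3 (0.27 log units; that floor lies within the scatter), an at least 1.5-fold higher number from compound 2 to compound 3 (0.20 log units; that floor lies within the scatter).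

Compound 4, `O=S(=O)(Nc1ccc2oc(-c3ccccc3)nc2c1)c1ccc(Cl)s1`, is not yet measured. It differs from compound 3 in one place: 5-chlorothiophen-2-yl in place of 3-hydroxyphenyl on a sulfonyl sulfur. Among the measured compounds shown here, the steps that bear on this change are the two that also swapped the group on the sulfonyl sulfur, from compound 1 to compound 3 and from compound 2 to compound 3, and both stayed within the scatter. The expectation for compound 4 in this assay is thus a step of an at least 1.1-fold lower number from compound 3 to compound 4 (0.07 log units; that floor lies within the scatter), no real change beyond the scatter. Compound 4 is estimated at 85000 nM, with a range from 40000 nM to 200000 nM, and a fair chance that again only a limit is reported.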

Compound 4, half-maximal cytotoxic concentration: > 100000 nM
Compound 4: a limit, no number (the forecaster's own chance of this, stated with the estimate: 45%); at least 1.1-fold (0.07 log units) between middle value and limit.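

In this assay compound 4 gives > 100000 nM, which is a limit and not a number. A second group on the sulfonyl sulfur, 5-chlorothiophen-2-yl, now reaches the same limit as 3-hydroxyphenyl, so neither a hydrogen-bond donor nor a six-membered aromatic ring of carbon only is needed in this place for that result: the limit of > 100000 nM in this assay, at which 2 of the 4 values shown sit. Against the two groups with real numbers, the result reads as an at least 1.5-fold higher number from compound 2 to compound 4 (0.20 log units; that floor lies within the scatter) and as an at least 1.8-fold higher number from compound 1 to compound 4 (0.27 log units; that floor lies within the scatter), so these two steps show no real difference, and the step between the two limits cannot be read.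

Going by these compounds, whether compound 3 and compound 4 differ at all stays open, as does whether any group on the sulfonyl sulfur can move the value beyond the scatter. An amine or a carboxylic acid on the aromatic ring held by the sulfur, or a longer alkyl chain in place of that ring, would test how far this tolerance in this assay extends.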